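Swapping the amide aryl group on a thiazole ester core

This account rests on a few compounds, and the source may have more. Where it says the series, first, only, none or still open, it means among the compounds named here.

Measured compounds:
compound 1 `CCOC(=O)c1sc(-c2cccc(NC(=O)c3ccccc3F)c2)nc1Nc1ccc(N2CCN(C)CC2)cc1`: 96.4%
compound 2 `CCOC(=O)c1sc(-c2cccc(NC(=O)c3ccc(C(F)(F)F)cn3)c2)nc1Nc1ccc(N2CCN(C)CC2)cc1`: 19%

In a functional assay on Ramos cells (Homo sapiens) for antiproliferative activity, read by CCK-8 assay, with a stated time of 72 h, tested at 40 uM (a lower number here means less inhibition, a higher number more inhibition at the concentration tested (going by the name of the read-out)), compound 1 gives 96.4%, while compound 2 gives 19%. For the measured compounds named here, compound 2 therefore stands lowest of the two numbers, and the only step measured so far, a number 77.4 percentage points lower from compound 1 to compound 2 (beyond the scatter), shows that exchanging the aryl group attached to the carbonyl carbon can move the read-out by a large amount in this assay.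

Compound 3 `CCOC(=O)c1sc(-c2cccc(NC(=O)c3ccco3)c2)nc1Nc1ccc(N2CCN(C)CC2)cc1` differs from compound 2 in the same place: furan-2-yl in place of 5-(trifluoromethyl)pyridin-2-yl on a carbonyl carbon. Going by the values given here, no measured step covers a furan-2-yl group here, so the direction of the change is open; the one measured step only says that this position is sensitive. The expectation is a step of a number 36 percentage points higher from compound 2 to compound 3 (beyond the scatter), giving compound 3 an estimated 55%, with a range from 10% to 95%.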

Compound 3, a percentage reported as inhibition, at one concentration (the size of the read-out at that concentration, not a potency): 50.2%
The estimate for compound 3 lay 4.8 percentage points above the measured number; low and high end bracket the measured number.
By their numbers in this assay, from the lowest: compound 2; then compound 3; then compound 1.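

In this assay, the furan-2-yl group gives a number 31.2 percentage points higher from compound 2 to compound 3 (beyond the scatter) when it replaces 5-(trifluoromethyl)pyridin-2-yl, and a number 46.2 percentage points lower from compound 1 to compound 3 (beyond the scatter) when it replaces 2-fluorophenyl. This position therefore does more than switch the read-out between high and low: the three groups give three clearly separated levels, and ring size alone does not set their order, since the five-membered ring of compound 3 falls between the six-membered rings of compound 2 and compound 1. No available evidence explains this order.

The compounds shown leave open whether a plain phenyl group would behave like 2-fluorophenyl or like furan-2-yl. They also leave open what a non-aromatic group on the carbonyl carbon, such as cyclohexyl or a short ethyl chain, would do to the read-out.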